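This account rests on a few compounds, and the source may have more. Where it says the series, first, only, none or still open, it means among the compounds named here.

Measured in a functional assay on KB cells (Homo sapiens) for inhibition, read by MTT assay, with a stated time of 24 h, tested at 10 ug/mL; a higher number here means more inhibition of growth at the concentration tested, a lower number less inhibition of growth:
compound 1 `CC(=O)SCCC(CCCCC(=O)O)SC(C)=O`: 8.88%
compound 2 `O=C(CCCCC(S)CCS)Nc1ccc(Cl)cc1`: 18.2%

In this assay, compound 2 gives 18.2%, a value within the usual scatter of compound 1 at 8.88%. Compound 3 `O=C(CCCCC(S)CCS)Nc1ccc([N+](=O)[O-])cc1` has not yet been measured. It carries one structural change from compound 2, with nitro in place of chloro on an aromatic carbon. Going by the values given here, no measured pair of compounds shows what such a change does, so no shift beyond the scatter is expected. The expected step is a number 1.8 percentage points higher from compound 2 to compound 3 (within the scatter). The estimate for compound 3 is 20%, with an expected range of 6% to 38%.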

Compound 3, percent growth inhibition at one concentration: 13.7%
The estimate for compound 3 lay 6.3 percentage points above the measured number; the range from low to high includes it.
By their numbers in this assay, from the lowest: compounds 1, 3 and 2 (each within the scatter of the next).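

In this assay, going by these compounds alone, putting nitro in place of chloro on this aromatic carbon, para to a large group, gives the first measured step for this change: a number 4.5 percentage points lower from compound 2 to compound 3 (within the scatter). At this position, then, exchanging the single chlorine atom for the larger nitro group, which brings hydrogen-bond acceptors, leaves the reading within the usual scatter. No measurement of any property of these groups bears on this result. Still open, as far as these compounds go, is whether an amine or a methoxy group at this same ring position would move the number beyond the scatter.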